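This account rests on a few compounds, and the source may have more. Where it says the series, first, only, none or still open, it means among the compounds named here.

Measured compounds:
compound 1, `CCCc1nc(-c2ccccc2)c(CNCCN2CCN(c3cccc(C(F)(F)F)c3)CC2)o1`: 56.3%
compound 2, `CCCc1nc(-c2ccccc2)c(CNCCN2CCN(c3ccccc3F)CC2)o1`: 46.5%
compound 3, `CCCc1nc(-c2ccccc2)c(CNCCCN2CCN(c3cccc(C(F)(F)F)c3)CC2)o1`: 51.6%

All three were read in an assay on HEK293 cells for inhibition of Voltage-dependent T-type calcium channel subunit alpha-1G (Homo sapiens), read by fluorescence, tested at 10 uM; on this read-out higher numbers stand for more inhibition at the one concentration tested (going by the name of the read-out) and lower numbers for less inhibition. Compound 3 sits between compound 1 and compound 2 on these numbers, and both gaps fall within the usual scatter, so none of the three is told apart from the others. Compound 4, `CCCc1nc(-c2ccccc2)c(CNCCCN2CCN(c3ccc(OC)cc3)CC2)o1`, differs from compound 3 in one place: 4-methoxyphenyl in place of 3-(trifluoromethyl)phenyl on an amine nitrogen in a ring. For the measured compounds named here, the only measured step that bears on the group on the amine nitrogen in the ring is a number 9.8 percentage points lower from compound 1 to compound 2 (within the scatter), and it stayed within the scatter. Compound 4 is therefore expected to remain in the same band, with an estimated step of a number 6.6 percentage points lower from compound 3 to compound 4 (within the scatter) that does not exceed the scatter. The estimate for compound 4 is 45%, with a range of 30% to 60%.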

Compound 4, a percentage reported as inhibition, at one concentration (the size of the read-out at that concentration, not a potency): 42.1%
Compound 4: the middle estimate sits 2.9 percentage points above what was measured; the range from low to high includes it.
By their numbers in this assay, from the lowest: compounds 4, 2, 3 and 1 (each within the scatter of the next, the first and the last beyond it).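

In this assay the 4-methoxyphenyl swap on the amine nitrogen in the ring gives a number 9.5 percentage points lower from compound 3 to compound 4 (within the scatter) and so does not separate the two groups. This is a second aryl change at this position that stays within the scatter, now with a hydrogen-bond acceptor entering and the fluorine atoms leaving. No measurement here explains the size of this step.

The swap alters the substituent and its ring position together, so their contributions remain unseparated. Unsubstituted phenyl, a pyridine ring or a non-aromatic group such as cyclohexyl at this nitrogen remains open.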